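A few compounds are considered here, and "the series" means these few. Any claim that something is new, unique, unknown or untested is made for them only; others in the source may bear on it.

In a functional assay on U-251 cells (Homo sapiens) for antiproliferative activity, read by MTT assay, with a stated time of 24 h (a lower number here means a stronger inhibitor, a higher number a weaker inhibitor), compound 1 (`COc1cc(OC)c(-c2coc3cc(OCc4ccccc4C)ccc3c2=O)cc1OC`) gives 2000 nM and compound 2 (`COc1cc(OC)c(-c2coc3cc(OCc4ccc([N+](=O)[O-])cc4)ccc3c2=O)cc1OC`) gives 9400 nM, so compound 2 holds the higher of the two numbers and is the weaker inhibitor so far. Compound 3 (`COc1cc(OC)c(-c2coc3cc(OCc4ccc(C#N)cc4)ccc3c2=O)cc1OC`) differs from compound 2 in one place: cyano in place of nitro on an aromatic carbon, para to a large group (cyano in place of nitro on an aromatic carbon). Among the measured compounds shown here, only one measured step bears on this, a 4.7-fold higher number from compound 1 to compound 2 (0.67 log units; beyond the scatter). That step replaced 2-methylphenyl with 4-nitrophenyl, so it shows that this part of the molecule can shift the number, but it does not test nitro against cyano. With no direct evidence for a large shift, the step expected in this assay is small, possibly a slight drop: a 1.3-fold lower number from compound 2 to compound 3 (0.13 log units; within the scatter). For compound 3 the estimated value is 7000 nM, with an expected range of 2500 nM to 18000 nM.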

Compound 3, half-maximal inhibitory concentration: 6180 nM
Compound 3: the middle estimate sits 1.1-fold (0.05 log units) above what was measured; measured number inside the range.
By their numbers in this assay, from the lowest: compound 1; then compounds 3 and 2 (each within the scatter of the next).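

In this assay, exchanging nitro for cyano on the aromatic carbon para to a large group gives a 1.5-fold lower number from compound 2 to compound 3 (0.18 log units; within the scatter), so this change does not separate compound 2 from compound 3. The other new comparison, a 3.1-fold higher number from compound 1 to compound 3 (0.49 log units; beyond the scatter), shows that 4-cyanophenyl, like 4-nitrophenyl, goes with a higher number than 2-methylphenyl, so the earlier rise is not unique to nitro. No measurement here gives a cause for either step.

Because 2-methylphenyl differs from the other two groups in both the group it carries and where that group sits, these compounds leave open which of the two matters. They also leave open how an amine or a carboxylic acid on that same aromatic carbon would read in this assay.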